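This account rests on a few compounds, and the source may have more. Where it says the series, first, only, none or still open, it means among the compounds named here.

Of the compounds shown here, three have been tested in a functional assay on the whole organism (strain Wistar Albino) for inhibition, with Rattus norvegicus as the target, read by paw edema, with a stated time of 4 h, at a dose of 20 mg/kg; on this read-out lower numbers stand for less inhibition and higher numbers for more inhibition at the one dose given (going by the name of the read-out). Compound 1 `Cc1cc(-c2nn3c(-c4ccoc4C)nnc3s2)c2ccccc2n1` gives 26.3%, and compound 2 `Cc1occc1-c1nnc2sc(-c3ccnc4ccccc34)nn12` gives 23.4%. Compound 3 `COc1ccc(Cl)c(-c2nnc3sc(Cc4c[nH]c5ccc(OC)cc45)nn23)c1` gives 33.9%, a value beyond the scatter above that of compound 2. How the core of compound 3 differs from that of compound 2 is not broken down here. Compounds 2 and 1 differ by one change, (methyl in place of hydrogen on an aromatic carbon), and it made a step of a number 2.9 percentage points higher from compound 2 to compound 1 (within the scatter). Compound 4 `COc1ccc(Cl)c(-c2nnc3sc(Cc4c(C)[nH]c5ccc(OC)cc45)nn23)c1` stands to compound 3 by the change (methyl in place of hydrogen on an aromatic carbon); this is the same kind of change, though here it sits on a five-membered aromatic ring with one nitrogen rather than on a six-membered one. Because the earlier step was a number 2.9 percentage points higher from compound 2 to compound 1 (within the scatter), a step of similar small size is expected for compound 4, a number 2.1 percentage points higher from compound 3 to compound 4 (within the scatter). Compound 4 is thus estimated at 36% in this assay.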

Compound 4, a percentage reported as inhibition, in the whole organism at one dose (the size of the read-out at that dose, not a potency): 32.7%
Estimate against measurement, compound 4: 3.3 percentage points above; low and high end bracket the measured number.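

In this assay, methyl in place of hydrogen on an aromatic carbon gave a number 1.2 percentage points lower from compound 3 to compound 4 (within the scatter). Set beside the earlier step, the same change shows no difference that can be told apart between the two cores: the same change on two cores in this assay, a number 2.9 percentage points higher (within the scatter) from compound 2 to compound 1 and a number 1.2 percentage points lower (within the scatter) from compound 3 to compound 4, 4.1 percentage points apart, within the scatter of two such steps. Among the compounds shown here, this shows that on these two cores the methyl leaves the read-out within the scatter, but with only two pairs at one dose, it does not show that the step would stay as small on any other core, nor does it give a potency.

The compounds shown leave open whether an ethyl group or a carboxylic acid on the same aromatic carbon would shift the read-out beyond the scatter. They also leave open how an amine would behave there.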